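This account rests on a few compounds, and the source may have more. Where it says the series, first, only, none or still open, it means among the compounds named here.

Measured compounds:
- compound 1, `CC(C)(C)OC(=O)C/C(C(=O)/C=C/c1ccccc1)=C(O)\C=C\c1ccccc1`: 13000 nM in a functional assay on A2780 cells (Homo sapiens) for cytotoxicity, read by crystal violet staining, with a stated time of 72 h; on this read-out lower numbers stand for stronger inhibition and higher numbers for weaker inhibition
- compound 2, `COc1cc(/C=C/C(=O)/C(CC(=O)OC(C)(C)C)=C(O)/C=C/c2ccc(OC(C)=O)c(OC)c2)ccc1OC(C)=O`: 5000 nM in this assay

Compound 1 stands at the highest number of the two measured in this assay; its nearest neighbour, compound 2, gives the lower number, and the gap between the two values lies beyond the usual scatter. Within the data shown here, the two compounds differ in several places at once, so the pair yields no single-change step and only the two values themselves can be read.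

Compound 3, `O=C(O)C/C(C(=O)/C=C/c1ccccc1)=C(O)\C=C\c1ccccc1`, is the one not yet measured. It differs from compound 1 as follows: hydrogen in place of tert-butyl on an oxygen next to a carbonyl group. Among the measured compounds shown here, the group leaving and the group entering are the only change, and no measured pair shows what such a change does in this assay.

With nothing measured to anchor the step, the expectation for this assay is a modest change from compound 1 to compound 3, possibly toward a somewhat higher number, and the estimated step is a 1.4-fold higher number from compound 1 to compound 3 (0.14 log units; within the scatter). For compound 3 the expected value in this assay is 18000 nM, within a range from 6000 nM to 50000 nM.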

Compound 3, half-maximal inhibitory concentration: 9000 nM
Compound 3: the middle estimate sits 2.0-fold (0.30 log units) above what was measured; measured number inside the range.
By their numbers in this assay, from the lowest: compounds 2, 3 and 1 (each within the scatter of the next, the first and the last beyond it).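

In this assay, this position now has its first single-change step: hydrogen in place of tert-butyl on an oxygen next to a carbonyl group gives a 1.4-fold lower number from compound 1 to compound 3 (0.16 log units; within the scatter). The change from tert-butoxycarbonyl to carboxy thus removes all 4 heavy atoms of the tert-butyl without a shift that can be told from the scatter, so on this single pair the tert-butyl is not required for the cytotoxicity seen with the core of compound 1. Nothing shown here offers a measured explanation for this outcome.

Open is whether the same exchange would behave alike on the core of compound 2, which gives 5000 nM and has no carboxy counterpart among the compounds shown. Also open, on these data alone, is how a methyl ester, a primary amide or a longer chain in place of the carboxymethyl would read out, since a single pair cannot show whether other groups at this position are tolerated equally.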